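The compounds below may be only part of what the source reports. "The series", "measured", "known", "first", "only" and "open" are said of these compounds alone.

Three compounds share one core and differ in a single side chain. Among the measured compounds shown here, in a functional assay on MCF7 cells (Homo sapiens) for cytotoxicity, read by MTT assay, with a stated time of 72 h (a higher number here means a weaker inhibitor, a lower number a stronger inhibitor), compound 3 `O=C(NCCCNc1c(C(=O)NCc2ccc(F)cc2)nc(Br)c2cccnc12)c1ccccc1` gives 2000 nM, the lower of the only two numbers available. Compound 1 `Nc1cccc(Nc2c(C(=O)NCc3ccc(F)cc3)nc(Br)c3cccnc23)c1` gives 8000 nM, and this gap lies beyond the usual scatter of repeated measurements. For compound 2 `O=C(NCc1ccc(F)cc1)c1nc(Br)c2cccnc2c1NCCO` the entry reads "not determined" (no result reported), so the comparison rests on a single pair of values.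

Compound 4 `COC(=O)CNc1c(C(=O)NCc2ccc(F)cc2)nc(Br)c2cccnc12` keeps the shared core but differs from compound 3 in one place: methoxycarbonyl in place of 2-benzamidoethyl on a saturated chain carbon bound to a nitrogen on an aromatic ring. The group that leaves is much larger and carries an aromatic ring, while the group that enters has no ring.

For the measured compounds named here, no measured pair shows directly what this swap does, so any forecast is tentative. Going by the values given here, compound 3 holds the lowest number so far at 2000 nM, which leaves more room for a rise than a fall. A moderate rise in this assay is therefore expected, probably beyond the scatter, towards a weaker inhibitor. The expected change is a 3.0-fold higher number from compound 3 to compound 4 (0.48 log units; beyond the scatter). For compound 4, the estimated half-maximal inhibitory concentration is 6000 nM, with an expected range of 1800 nM to 20000 nM.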

Compound 4, half-maximal inhibitory concentration: > 10000 nM
Compound 4: a limit, no number (the forecaster's own chance of this, stated with the estimate: 15%); middle value at least 1.6-fold (0.22 log units) from the limit.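

In this assay, the entry for compound 4 is a limit of the assay and not a number: the limit of > 10000 nM in this assay, at which 1 of the 4 values shown sits.

Among the compounds shown here, replacing 2-benzamidoethyl with methoxycarbonyl on a saturated chain carbon bound to a nitrogen on an aromatic ring gives an at least 5.0-fold higher number from compound 3 to compound 4 (0.69 log units; beyond the scatter), the first comparison here showing that a change at this place can move the read-out beyond the scatter, though the limit hides the full size of the step. The comparison with (methoxycarbonyl)methyl in place of 3-aminophenyl on a nitrogen on an aromatic ring gives an at least 1.2-fold higher number from compound 1 to compound 4 (0.09 log units; that floor lies within the scatter), so this pair sets no firm order, and the real gap could be small or large.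

The compounds shown leave open which part of 2-benzamidoethyl goes with the lower number: its aromatic ring, its amide or the length of its chain. A chain ending in a plain amine, with no benzoyl group, would help separate these parts, and a carboxylic acid in place of the methoxycarbonyl would test whether the ester itself matters.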